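Swapping a Sulfanyl Group for a Longer Nitrophenyl Chain

The source may report more compounds than this note shows. Statements on the series, on what has been measured and on what is new or still open speak of the compounds shown alone.

Three esters built on one shared core have been tested in a functional assay on PC-3 cells (Homo sapiens) for inhibition, read by MTT assay, with a stated time of 48 h; a higher number here means a weaker inhibitor, a lower number a stronger inhibitor. Compound 1 `C=C1CC[C@@H]2[C@](C)(CO)[C@H](O)CC[C@@]2(C)[C@@H]1C/C=C1/C(=O)OC[C@H]1OC(=O)CSc1ccc(C)cc1` gives 27000 nM. Compound 2 `C=C1CC[C@@H]2[C@](C)(CO)[C@H](O)CC[C@@]2(C)[C@@H]1C/C=C1/C(=O)OC[C@H]1OC(=O)CSc1ccc(F)cc1` gives 14000 nM, and compound 3 `C=C1CC[C@@H]2[C@](C)(CO)[C@H](O)CC[C@@]2(C)[C@@H]1C/C=C1/C(=O)OC[C@H]1OC(=O)CSc1cccs1` gives 18000 nM. Compound 3 thus holds the second highest of the three numbers, closest to compound 2 and furthest from compound 1, with both gaps inside the scatter. The changes among these three were all small: a 1.9-fold lower number from compound 1 to compound 2 (0.29 log units; within the scatter), a 1.3-fold higher number from compound 2 to compound 3 (0.11 log units; within the scatter), and a 1.5-fold lower number from compound 1 to compound 3 (0.18 log units; within the scatter).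

Compound 4 `C=C1CC[C@@H]2[C@](C)(CO)[C@H](O)CC[C@@]2(C)[C@@H]1C/C=C1/C(=O)OC[C@H]1OC(=O)CCCSc1ccc([N+](=O)[O-])cc1` differs from compound 3 in that (2-((4-nitrophenyl)sulfanyl)ethyl in place of (thiophen-2-yl)sulfanyl on a saturated chain carbon bound to a carbonyl carbon). For the measured compounds named here, no measured step matches this change, since the earlier steps exchanged only the aromatic group on the sulfur and left the chain untouched. Those steps stayed within the scatter, so a shift of comparable size is expected in this assay in either direction; the expected step is a 1.2-fold lower number from compound 3 to compound 4 (0.08 log units; within the scatter). Compound 4 is estimated at 15000 nM, within a range from 5000 nM to 45000 nM.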

Compound 4, half-maximal inhibitory concentration: 17000 nM
For compound 4 the middle estimate is 1.1-fold (0.05 log units) below the measured one; the range from low to high includes it.
By their numbers in this assay, from the lowest: compounds 2, 4, 3 and 1 (each within the scatter of the next).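

In this assay the longer chain makes no clear difference against any of the three earlier esters (a 1.1-fold lower number from compound 3 to compound 4 (0.02 log units; within the scatter); a 1.2-fold higher number from compound 2 to compound 4 (0.08 log units; within the scatter); a 1.6-fold lower number from compound 1 to compound 4 (0.20 log units; within the scatter)). The earlier compounds shown here changed only the aromatic group on the sulfur, whereas compound 4 shows that the number also stays within the scatter when the 2-((4-nitrophenyl)sulfanyl)ethyl group enters on this saturated chain carbon bound to a carbonyl carbon. No outside evidence bears on this result.

Going by these compounds, compound 4 changes the chain and the aromatic ring together, so the effect of each alone remains unknown. On these data alone, it also remains open whether a carboxylic acid or an amine at the end of the chain, in place of the sulfanyl-bearing aromatic group, would shift the number beyond the scatter.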